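The source may report more compounds than this note shows. Statements on the series, on what has been measured and on what is new or still open speak of the compounds shown alone.

Of the compounds shown here, two have numbers so far. Compound 1 `C=C1C(=O)ON(C)C1C(C)C` and compound 2 `C=C1C(=O)ON(C)C1c1ccccc1` differ in the group that sits on the shared core. In a functional assay on L1210 cells (Mus musculus) for antiproliferative activity (on this read-out lower numbers stand for stronger inhibition and higher numbers for weaker inhibition), compound 1 gives 2630 nM, while compound 2 gives 5500 nM. Compound 2 therefore stands at the highest of the two numbers, the weaker of the pair, with its gap to compound 1 beyond the scatter. Going by the values given here, no step between two measured compounds that differ in one place exists, so nothing in the measured pair speaks directly to the change now made. Compound 3 `C=C1C(=O)ON(C)C1c1ccc(Br)cc1` is obtained from compound 2 by bromo in place of hydrogen on an aromatic carbon. Among the compounds with values here, with no comparable step in the measured set, the expectation is a step of modest size, if any, and somewhat more likely toward a lower number than a higher one. Compound 3 is therefore expected to reach about 3500 nM in this assay, within a range from 1200 nM to 10000 nM. The step this implies, a 1.6-fold lower number from compound 2 to compound 3 (0.20 log units; within the scatter), is expected to sit close to the edge of the scatter. Whether it does will be seen once compound 3 is measured.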

Compound 3, half-maximal inhibitory concentration: 700 nM
For compound 3 the middle estimate is 5.0-fold (0.70 log units) above the measured one; the whole stated range lies above it.
By their numbers in this assay, from the lowest: compound 3; then compound 1; then compound 2.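

In this assay, going by these compounds alone, bromo in place of hydrogen on an aromatic carbon of the six-membered aromatic ring, para to a group of 8 heavy atoms, gives a 7.9-fold lower number from compound 2 to compound 3 (0.90 log units; beyond the scatter) and so supplies the only step so far that changes one place on an otherwise unchanged structure. This position therefore responds to substitution: the change brings in no ring, no hydrogen-bond donors or acceptors and no net charge, yet the step lies well beyond the scatter, something the earlier pair, which differs in the whole group on the shared core, could not show. Nothing measured in this set bears on the origin of this step.

The compounds shown leave open whether the step belongs to bromo itself or would also follow from another group at the same carbon, such as chloro, methoxy, an amine or a carboxylic acid. They also leave open whether bromo on another carbon of the same aromatic ring, or a second halogen added to compound 3, would move the number further in either direction.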